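Cyclohexyl in Place of Butyl on the Sulfur

The source may hold more compounds than are shown below. What is called first, only, known or untested is meant among the compounds shown, and "the series" means these compounds.

Three compounds share one core and differ only in the group on one aromatic carbon. Compound 1 `CCCCN(C)c1cc(C(F)(F)F)ccc1CNC(=O)C(C)c1ccc(NS(C)(=O)=O)c(F)c1` carries butyl(methyl)amino there and gives 1.2 nM in an assay on CHO cells for antagonist activity at transient receptor potential cation channel subfamily V member 1 (Homo sapiens), read by FLIPR; a lower number here means a stronger inhibitor, a higher number a weaker inhibitor. Compound 2 `CC(C(=O)NCc1ccc(C(F)(F)F)cc1N1CCN(c2ccccc2)CC1)c1ccc(NS(C)(=O)=O)c(F)c1` carries 4-phenylpiperazin-1-yl and gives 2 nM. Compound 3 `CCCCSc1cc(C(F)(F)F)ccc1CNC(=O)C(C)c1ccc(NS(C)(=O)=O)c(F)c1` carries butylsulfanyl and gives 1.9 nM. Compound 3 stands second highest of these three numbers, yet the steps between them are small: a 1.7-fold higher number from compound 1 to compound 2 (0.22 log units; within the scatter), a 1.6-fold higher number from compound 1 to compound 3 (0.20 log units; within the scatter) and a 1.1-fold lower number from compound 2 to compound 3 (0.02 log units; within the scatter), each within the scatter, so none of the three can be called stronger or weaker than the others.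

Compound 4 `CC(C(=O)NCc1ccc(C(F)(F)F)cc1SC1CCCCC1)c1ccc(NS(C)(=O)=O)c(F)c1` keeps the sulfur on the aromatic carbon and changes what hangs from it: cyclohexyl in place of butyl on a sulfur. Among the compounds with values here, no measured pair alters the group on the sulfur itself, so there is no direct guide for this change. The nearest evidence is that the three measured exchanges at this aromatic carbon, which swapped groups far more different from one another, all stayed within the scatter in this assay. The step of a 1.1-fold higher number from compound 3 to compound 4 (0.02 log units; within the scatter) is therefore expected to stay within the scatter as well. Compound 4 in this assay is estimated at 2 nM, with a range from 0.7 nM to 6 nM.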

Compound 4, inhibition constant: 0.5 nM
Compound 4: middle estimate off by 4.0-fold (0.60 log units), on the high side, outside the stated range (below it).
By their numbers in this assay, from the lowest: compound 4; then compounds 1, 3 and 2 (each within the scatter of the next).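

Until now every exchange at this aromatic carbon had stayed within the scatter, so it was unclear whether this assay could separate groups here at all. Changing only what hangs on the sulfur gives a 3.8-fold lower number from compound 3 to compound 4 (0.58 log units; beyond the scatter), and the other two comparisons agree, with a 4.0-fold lower number from compound 2 to compound 4 (0.60 log units; beyond the scatter) and a 2.4-fold lower number from compound 1 to compound 4 (0.38 log units; beyond the scatter), so compound 4 stands apart from all three earlier compounds even though compound 3 carries the same sulfur. Nothing shown here explains why cyclohexyl on this sulfur gives the lower number.

The compounds shown cannot say whether the ring itself matters or simply the larger count of carbons: a straight hexyl chain on the sulfur would separate the two, and a cyclopentyl or phenyl group there would show how much the ring's size and type count. On these data alone, it also remains open whether the sulfur is needed for this result, which a cyclohexylamino group on the same aromatic carbon would test.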